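A few compounds are considered here, and "the series" means these few. Any claim that something is new, unique, unknown or untested is made for them only; others in the source may bear on it.

Measured compounds:
- compound 1, `CCCCCCCCNC(=O)/C=C/c1c(/C=C/c2ccc(OC)cc2)cc(OC)cc1OC`: 8660 nM
- compound 2, `CCCCN(CCCC)C(=O)/C=C/c1c(/C=C/c2ccc(OC)cc2)cc(OC)cc1OC`: 6160 nM
- compound 3, `COc1ccc(/C=C/c2cc(OC)cc(OC)c2/C=C/C(=O)NC(C)C)cc1`: 2360 nM

All three were tested in a functional assay on A549 cells (Homo sapiens) for inhibition, read by MTT assay, with a stated time of 48 h; a higher number here means a weaker inhibitor, a lower number a stronger inhibitor. Compound 1 gives the highest number of the three; its nearest neighbour is compound 2, where a 1.4-fold lower number from compound 1 to compound 2 (0.15 log units; within the scatter), and its furthest is compound 3, where a 3.7-fold lower number from compound 1 to compound 3 (0.56 log units; beyond the scatter). Compound 2 and compound 3 are separated by a modest step as well, since a 2.6-fold lower number from compound 2 to compound 3 (0.42 log units; beyond the scatter).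

The new compound is compound 4, `COc1ccc(/C=C/c2cc(OC)cc(OC)c2/C=C/C(=O)N(CC(C)C)CC(C)C)cc1`. Relative to compound 1 it differs at one place: diisobutylamino in place of octylamino on a carbonyl carbon. For the measured compounds named here, the step that bears most directly on this change is the one from compound 1 to compound 2, where a dialkylamino likewise replaced octylamino on the same carbonyl carbon and the number fell only within the scatter. The modest gains seen on going to compound 3 came from a smaller isopropylamino group, not from a branched dialkylamino, so they are weaker guides. The account therefore expects compound 4 to sit close to compound 1 and compound 2, with at most a small step down in this assay: a 1.6-fold lower number from compound 1 to compound 4 (0.20 log units; within the scatter). The estimate for compound 4 in this assay is 5500 nM, within a range from 2000 nM to 15000 nM.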

Compound 4, half-maximal inhibitory concentration: 3350 nM
Compound 4: the middle estimate sits 1.6-fold (0.22 log units) above what was measured; low and high end bracket the measured number.
By their numbers in this assay, from the lowest: compounds 3, 4, 2 and 1 (each within the scatter of the next, the first and the last beyond it).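

In this assay, a 2.6-fold lower number from compound 1 to compound 4 (0.41 log units; beyond the scatter) shows that exchanging octylamino for diisobutylamino on the carbonyl carbon can move the number beyond the scatter, even though the two groups have the same count of heavy atoms. Removing the amide hydrogen does not in itself give a step of that size, as compound 2 also lacks it, and a 1.4-fold lower number from compound 1 to compound 2 (0.15 log units; within the scatter) stays within the scatter. The other two steps are a 1.8-fold lower number from compound 2 to compound 4 (0.26 log units; within the scatter) and a 1.4-fold higher number from compound 3 to compound 4 (0.15 log units; within the scatter), both within the scatter, so compound 4 cannot be separated from compound 2 or compound 3, and nothing shown explains the difference from compound 1.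

Going by these compounds, it remains open whether a shorter group such as dimethylamino would fall closer to compound 3 or to compound 1. On these data alone, the effect of a carboxylic acid at the end of the octyl chain also remains open.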